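The compounds below may be only part of what the source reports. "The series", "measured", "known", "first", "only" and "open" are said of these compounds alone.

Compound 3 `CCc1ccccc1OC(C)C1=NCCN1` stands level with compound 1 `CCOc1ccccc1OC(C)C1=NCCN1` and compound 2 `CC(C)Oc1ccccc1OC(C)C1=NCCN1` in an assay on CHO cells with Alpha-2B adrenergic receptor (Homo sapiens) as the target; on this read-out lower numbers stand for smaller maximal responses and higher numbers for larger maximal responses: compound 3 gives 0.5, compound 1 gives 0.5 and compound 2 gives 0.5. The steps of no change at the digits printed from compound 1 to compound 3 (within the scatter) and no change at the digits printed from compound 2 to compound 3 (within the scatter) both stay within the scatter, as does no change at the digits printed from compound 1 to compound 2 (within the scatter). Compound 4 `CC(Oc1ccccc1C=O)C1=NCCN1` differs from compound 3 by formyl in place of ethyl on an aromatic carbon. Going by the values given here, no measured step brings in a formyl; the two steps that swap the group on an aromatic carbon bear most closely on it, and both were flat, so the expected step of no change at the digits printed from compound 3 to compound 4 (within the scatter) is small, with no direction beyond the scatter. Compound 4 is therefore estimated at 0.5, with a range from 0.3 to 0.7.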

Compound 4, intrinsic activity: the largest response reached, as a fraction of the reference agonist's: 0.5
Beside the measured number, compound 4's estimate shows no gap at the digits printed; measured number inside the range.
By their numbers in this assay, from the lowest: compounds 1, 2, 3 and 4 (each within the scatter of the next).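

In this assay, formyl brings the first double bond outside aromatic rings to this aromatic carbon, yet the step stays flat: no change at the digits printed from compound 3 to compound 4 (within the scatter). Set against the two ether groups, the result is the same: no change at the digits printed from compound 2 to compound 4 (within the scatter) and no change at the digits printed from compound 1 to compound 4 (within the scatter). The level read-out across these four compounds therefore extends to a carbonyl-bearing group at this position, and no evidence available here accounts for it.

Going by these compounds, whether an amine, a carboxylic acid or a longer chain on this aromatic carbon would keep the same level remains open.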